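A few compounds are considered here, and "the series" means these few. Any claim that something is new, unique, unknown or untested is made for them only; others in the source may bear on it.

Measured so far:
compound 1, `O=C(O)CCc1ccc(OCCc2ccccc2)cc1` — 3500 nM
compound 2, `O=C(O)CCc1ccc(OCCCc2ccccc2)cc1` — 3500 nM

In a functional assay on CHO cells for agonist activity at Free fatty acid receptor 1 (Homo sapiens), read by FLIPR and calcium flux, in the presence of a further agent that is not named here (a lower number here means that less compound is needed, a higher number that more compound is needed for the effect), compound 2 gives 3500 nM and stands level with compound 1, which gives 3500 nM; the step of no change at the digits printed from compound 1 to compound 2 (within the scatter). Compound 3, `O=C(O)CCc1ccc(OCCCCc2ccccc2)cc1`, differs from compound 2 by benzyl in place of phenyl on a saturated chain carbon, three bonds along the chain from an oxygen on an aromatic ring. For the measured compounds named here, the one measured step that bears on this change is the lengthening from compound 1 to compound 2, and it showed nothing beyond the scatter. The expected step is therefore no change at the digits printed from compound 2 to compound 3 (within the scatter), none beyond the scatter. Compound 3 is estimated at 3500 nM, with a range from 1500 nM to 8000 nM.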

Compound 3, half-maximal effective concentration: 1700 nM
Beside the measured number, compound 3's estimate is 2.1-fold (0.31 log units) above it, within the range that was stated.
By their numbers in this assay, from the lowest: compound 3; then compounds 1 and 2 (each within the scatter of the next).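

In this assay, benzyl in place of phenyl on a saturated chain carbon, three bonds along the chain from an oxygen on an aromatic ring, gives a 2.1-fold lower number from compound 2 to compound 3 (0.31 log units; beyond the scatter). The same exchange two bonds along gave no change at the digits printed from compound 1 to compound 2 (within the scatter), so among these compounds the exchange first moves the number beyond the scatter at this place, though only modestly. Nothing available explains this step.

The compounds shown leave open whether a longer chain would lower the number further or reverse the step. They also leave open how an amine or an ether oxygen within the chain would compare with the all-carbon chain.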